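The source may report more compounds than this note shows. Statements on the series, on what has been measured and on what is new or still open speak of the compounds shown alone.

Two compounds of this series carry the shared core with a hydroxy-methoxyphenyl vinyl ketone arm on one side and a hydroxy-methoxystyryl arm on the other, differing at the pendant aryl ring and at the thiocarbonyl versus carbonyl of the ring. Compound 1 `COc1cc(/C=C/C(=O)C2=C(/C=C/c3ccc(O)c(OC)c3)NC(=O)NC2c2ccccc2)ccc1O` gives 50.2% in a functional assay, with a stated time of 20 min, tested at 50 uM; a lower number here means a weaker effect, a higher number a stronger effect of the compound at the concentration tested. Compound 2 `COc1cc(/C=C/C(=O)C2=C(/C=C/c3ccc(O)c(OC)c3)NC(=S)NC2c2ccc(C)cc2)ccc1O` gives 41% in this assay. The two numbers lie within the usual scatter of each other, so compound 1 and compound 2 are not told apart on these data, and compound 2 cannot be called the weaker of the two.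

Compound 3 `COc1cc(/C=C/C(=O)C2=C(/C=C/c3ccc(O)c(OC)c3)NC(=S)NC2c2ccc(N(C)C)cc2)ccc1O` has not yet been measured. It differs from compound 2 in one place: dimethylamino in place of methyl on an aromatic carbon. The change sits on an aromatic carbon of a six-membered aromatic ring of carbon only, para to a large group. Going by the values given here, no measured pair shows this change, so there is no step to lean on.

The expectation is a step from compound 2 to compound 3 of a number 3 percentage points higher from compound 2 to compound 3 (within the scatter), that is, no change beyond the scatter in either direction. Compound 3 is estimated at 44%, with a range from 25% to 63%.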

Compound 3, a percentage reported as activity, at one concentration (the size of the read-out at that concentration, not a potency): 84%
Estimate against measurement, compound 3: 40 percentage points below, outside the stated range (above it).
By their numbers in this assay, from the lowest: compounds 2 and 1 (each within the scatter of the next); then compound 3.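

In this assay, dimethylamino in place of methyl on the aromatic carbon para to a large group gives a number 43 percentage points higher from compound 2 to compound 3 (beyond the scatter). Going by these compounds alone, this is the first change that can be read at a single place, since the earlier pair differs both at the pendant aryl ring and at the carbonyl versus thiocarbonyl, and it shows that the read-out at the tested concentration can respond strongly to the group at this position. Nothing in the available data bears on the reason for a step of this size.

Open, on these data alone, is whether the step follows the nitrogen of the new group or the whole dimethylamino group, which an amino, methoxy or diethylamino group at the same place would help separate. Also open, as far as these compounds go, is whether dimethylamino at this position gives a similar step with the carbonyl in place of the thiocarbonyl, and whether the result at one concentration carries over to a potency.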